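The source may hold more compounds than are shown below. What is called first, only, known or untested is meant among the compounds shown, and "the series" means these compounds.

Compound 1 `CC(C)CN1CCCC[C@H]1C(=O)Nc1cc(C(C)(C)C)on1`: 32 ug/mL
Compound 2 `CC(C)(C)c1cc(NC(=O)[C@@H]2CCCCN2C(=O)CC2CCOCC2)no1`: 52 ug/mL
Compound 3 `CC(C)(C)c1cc(NC(=O)[C@@H]2CCCCN2C(=O)N2CCOCC2)no1`: 45 ug/mL

In a physicochemical assay for solubility, read by HPLC, at pH 6.8 (a lower number here means a less soluble compound, a higher number a more soluble compound), compound 1 gives 32 ug/mL, the lowest of the three numbers shown, although its gaps to compound 3 and to compound 2 both stay within the scatter. Compound 4 `CC(C)(C)c1cc(NC(=O)[C@@H]2CCCCN2C(=O)N2CCSCC2)no1` differs from compound 1 in one place: (thiomorpholin-4-yl)carbonyl in place of isobutyl on an amine nitrogen in a ring. Two measured steps resemble this change, each replacing the same isobutyl on the same ring nitrogen with a carbonyl-linked group: a 1.6-fold higher number from compound 1 to compound 2 (0.21 log units; within the scatter) and a 1.4-fold higher number from compound 1 to compound 3 (0.15 log units; within the scatter). Neither moved the number beyond the scatter, so for compound 4 a step of similar size is expected, a 1.1-fold higher number from compound 1 to compound 4 (0.04 log units; within the scatter), with no clear direction. Compound 4 is therefore estimated at 35 ug/mL, within a range from 15 ug/mL to 80 ug/mL.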

Compound 4, solubility: 46 ug/mL
Compound 4: middle estimate off by 1.3-fold (0.12 log units), on the low side; measured number inside the range.
By their numbers in this assay, from the lowest: compounds 1, 3, 4 and 2 (each within the scatter of the next).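

On an amine nitrogen in a ring, a third carbonyl-linked group gives a 1.4-fold higher number from compound 1 to compound 4 (0.16 log units; within the scatter) in this assay, so replacing isobutyl has now stayed within the scatter with each of these three groups. Changing only what sits on the carbonyl carbon also stays within the scatter, with a 1.0-fold higher number from compound 3 to compound 4 (0.01 log units; within the scatter) for sulfur in place of the morpholine ring oxygen and a 1.1-fold lower number from compound 2 to compound 4 (0.05 log units; within the scatter) for thiomorpholin-4-yl in place of (oxan-4-yl)methyl. No accompanying measurement explains these numbers. From the compounds shown here alone, whether a carboxylic acid or a piperazine on that carbonyl carbon would move the number beyond the scatter remains open.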